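The compounds below may be only part of what the source reports. "The series", "measured", "known", "first", "only" and "open" are said of these compounds alone.

Measured compounds:
Compound 1 `C=Cc1ccc(S(=O)(=O)Nc2ccc3oc(-c4ccccc4)nc3c2)cc1` — > 100000 nM
Compound 2 `O=S(=O)(Nc1ccc2oc(-c3ccccc3)nc2c1)c1cccc(F)c1` — > 100000 nM
Compound 3 `O=S(=O)(Nc1ccc2oc(-c3ccccc3)nc2c1)c1ccc(Cl)c(Cl)c1` — > 100000 nM

Compound 1 stands at a limit of the assay, not at a number: in an assay on cells for inhibition of HSP60/HSP10 (Homo sapiens), with a stated time of 60 min (on this read-out higher numbers stand for weaker inhibition and lower numbers for stronger inhibition), compound 1 gives > 100000 nM. Compound 2 likewise gives a limit in this assay, > 100000 nM. Compound 3 also gives a limit, > 100000 nM. All three sit at the limit of > 100000 nM in this assay, at which 3 of the 3 values shown sit. The steps a step that the two limits leave unreadable from compound 1 to compound 2, a step that the two limits leave unreadable from compound 1 to compound 3 and a step that the two limits leave unreadable from compound 2 to compound 3 are therefore unreadable in size and direction.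

Compound 4 `O=S(=O)(Nc1ccc2oc(-c3ccccc3)nc2c1)c1ccc(C(F)(F)F)cc1` differs from compound 1 by trifluoromethyl in place of vinyl on an aromatic carbon. The three measured steps bear on this change only in that every variation of the group on the sulfonyl sulfur so far has left the value at the limit; none gives a readable size. Compound 4 is therefore expected to remain at the limit as well, with the step of a number no higher from compound 1 to compound 4 (the limit leaves the size open) estimated as none beyond the scatter. The estimate for compound 4 in this assay is 100000 nM, within 30000 nM to 300000 nM.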

Compound 4, half-maximal inhibitory concentration: > 100000 nM
Compound 4: only a limit was reported; the forecaster's own chance of this, stated with the estimate: 85%; the middle value sits exactly at the limit.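

Within the data shown here, compound 4 gives > 100000 nM in this assay, a limit and not a number, and compound 1 also stands at a limit, so no step between them can be read. The compounds shown leave open which change, if any, would bring a value within the range of this assay.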